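The source may hold more compounds than are shown below. What is called first, only, known or untested is meant among the compounds shown, and "the series" means these compounds.

Of the compounds shown here, three of one series have been measured in an ADME assay for permeability, using PAMPA, with a stated time of 30 min, at pH 7.4; on this read-out higher numbers stand for higher permeability and lower numbers for lower permeability. Compound 1 `c1ccc(-c2ccc3c(NCCCNCc4ccco4)ccnc3c2)cc1` gives 237 10^-6 cm/s in this assay. Compound 2 `COc1ccc(F)cc1CNCCCNc1ccnc2cc(C3CCCCC3)ccc12` gives 23 10^-6 cm/s, and compound 3 `COc1cccc(CNCCCNc2ccnc3cc(Cc4ccc(F)cc4)ccc23)c1O` gives 23 10^-6 cm/s. On these numbers compound 2 stands level with compound 3 at the digits shown, the two together forming the bottom of the three, while compound 1 lies well above both, a gap that is beyond the usual scatter of the method.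

The account now follows the step from compound 2 to compound 4 `COc1ccc(F)cc1CNCCCNc1ccnc2cc(Cc3ccccc3)ccc12`, which has not yet been measured in this assay. Compound 4 differs from compound 2 in one place: benzyl in place of cyclohexyl on an aromatic carbon. For the measured compounds named here, no pair of measured compounds isolates this change, so its effect cannot be read from a measured step. What the numbers do show is that compound 2 and compound 3, whose substituents differ in several places, give the same number at the digits shown; in this assay compound 3 gives 23 10^-6 cm/s. On that basis the step from compound 2 to compound 4 is expected to be small, with a 1.1-fold higher number from compound 2 to compound 4 (0.04 log units; within the scatter) no larger than the scatter in either direction. Compound 4 is therefore estimated at 25 10^-6 cm/s in this assay, with a range from 10 10^-6 cm/s to 60 10^-6 cm/s.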

Compound 4, apparent permeability: 23 10^-6 cm/s
The estimate for compound 4 lay 1.1-fold (0.04 log units) above the measured number, and the stated range covers the measured number.
By their numbers in this assay, from the lowest: compounds 2, 3 and 4 (each within the scatter of the next); then compound 1.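

For the compounds shown here, this step is the first to isolate a single change, and it gives a direct reading at this position: in this assay, benzyl in place of cyclohexyl on an aromatic carbon gives no change at the digits printed from compound 2 to compound 4 (within the scatter), so the pair shows no measurable separation on this read-out. The exchange replaces a six-membered non-aromatic ring of carbon with a six-membered aromatic ring of carbon and takes the heavy-atom count of the group from 6 to 7, while both groups have no hydrogen-bond donors or acceptors and no net charge, so on this pair the read-out stays level across that difference in ring type and size. No measurement available here accounts for this outcome.

The compounds shown leave open whether a group of a different kind on this aromatic carbon, such as an amine or a carboxylic acid, would also leave the number level. They also leave open whether benzyl in place of cyclohexyl gives the same outcome when the rest of the molecule differs from that of compound 2.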